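The source may hold more compounds than are shown below. What is called first, only, known or untested is meant among the compounds shown, and "the series" means these compounds.

Of the compounds shown here, three have so far been tested in a functional assay on T-24 cells (Homo sapiens) for cytotoxicity, read by CCK-8 assay, with a stated time of 24 h; a lower number here means a stronger inhibitor, a higher number a weaker inhibitor. Compound 1 `C/C(=C\c1cc(-c2cccnc2)co1)C(N)=O` gives only a limit, > 50000 nM. Compound 2 `C/C(=C\c1cc(-c2ccc(C)nc2)co1)C(N)=O` likewise gives only a limit, > 50000 nM. The change between them is methyl in place of hydrogen on an aromatic carbon, and the step it made, a step that the two limits leave unreadable from compound 1 to compound 2, cannot be read from two limits. Compound 3 `C/C(=C\c1nc(-c2ccccc2)cs1)C(N)=O` also gives only a limit, > 50000 nM. How the core of compound 3 differs from the core of compound 1 is not broken down here. Compound 4 `C/C(=C\c1nc(-c2ccc(C)cc2)cs1)C(N)=O` is not yet measured; it carries the same kind of change as compound 2, namely (methyl in place of hydrogen on an aromatic carbon), but here the six-membered aromatic ring is of carbon only and the methyl is not next to a ring nitrogen. Because all three values sit at the limit of > 50000 nM in this assay, at which 3 of the 3 values shown sit, the expected step is a number no higher from compound 3 to compound 4 (the limit leaves the size open), with nothing readable. Compound 4 is accordingly expected to give about 50000 nM, most likely again only a limit.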

Compound 4, half-maximal inhibitory concentration: > 50000 nM
Compound 4: only a limit was reported; the forecaster's own chance of this, stated with the estimate: 90%; the middle value lies on the limit itself.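

Among the compounds shown here, compound 3 and compound 4 each give only a limit, so no step between them can be read. The compounds shown leave open whether any structural change shifts the result in this assay, because all of them share one limit: the limit of > 50000 nM in this assay, at which 4 of the 4 values shown sit.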